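Phenyl in place of nitro: notes on the series

The source may hold more compounds than are shown below. What is called first, only, known or untested is meant among the compounds shown, and "the series" means these compounds.

In a functional assay on MDA-MB-231 cells (Homo sapiens) for antiproliferative activity, read by MTT assay, with a stated time of 72 h (a higher number here means a weaker inhibitor, a lower number a stronger inhibitor), compound 3 (`O=C(CCc1cccc2c1B(O)OC2)Nc1ccc([N+](=O)[O-])cc1`) gives 36000 nM. Compound 1 (`O=C(CCc1cccc2c1B(O)OC2)Nc1ccc(I)cc1`) gives 33000 nM, and compound 2 (`COc1ccc(NC(=O)CCc2cccc3c2B(O)OC3)cc1`) gives 850 nM. Compound 3 therefore sits level with compound 1 at the high end of the numbers, far from compound 2.

Compound 4 (`O=C(CCc1cccc2c1B(O)OC2)Nc1ccc(-c2ccccc2)cc1`) follows from compound 3 by phenyl in place of nitro on an aromatic carbon, with phenyl in place of nitro on an aromatic carbon. Within the data shown here, three measured steps bear on this change. The exchange of iodo for nitro, a 1.1-fold higher number from compound 1 to compound 3 (0.04 log units; within the scatter), leaves the number within the scatter. The large steps both involve methoxy: a 39-fold lower number from compound 1 to compound 2 (1.59 log units; beyond the scatter) and a 42-fold higher number from compound 2 to compound 3 (1.63 log units; beyond the scatter). Among the measured compounds shown here, no measured compound carries a ring at this place, so the data do not show where phenyl will fall.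

A moderate step towards a lower number is expected, well short of the large steps, and the range allows for no change. The expected step is a 3.0-fold lower number from compound 3 to compound 4 (0.48 log units; beyond the scatter). In this assay the estimate for compound 4 is 12000 nM, with an expected range of 2500 nM to 50000 nM.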

Compound 4, half-maximal inhibitory concentration: 8800 nM
Estimate against measurement, compound 4: 1.4-fold (0.13 log units) above; the measured number falls inside the stated range.
By their numbers in this assay, from the lowest: compound 2; then compound 4; then compounds 1 and 3 (each within the scatter of the next).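

In this assay a ring at this place, the first among these compounds, gives a 4.1-fold lower number from compound 3 to compound 4 (0.61 log units; beyond the scatter) and a 3.8-fold lower number from compound 1 to compound 4 (0.57 log units; beyond the scatter) and so moves clear of the level shared by nitro and iodo. Phenyl does not reach methoxy, with a 10-fold higher number from compound 2 to compound 4 (1.02 log units; beyond the scatter) remaining, so the numbers now fall on three levels rather than two: compound 2, then compound 4, then compounds 1 and 3 together. No measurement at hand accounts for these levels.

Still open, going by these compounds, is whether the low number of compound 2 is particular to methoxy or is shared by ethoxy or hydroxyl at this place. Also open, on these data alone, is where an amine, a carboxylic acid or a saturated cyclohexyl ring would fall against these three levels.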